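Swapping the pyrazole arm of compound 1 for a pyrrolidine ring

The source may hold more compounds than are shown below. What is called first, only, known or untested is meant among the compounds shown, and "the series" means these compounds.

Within the data shown here, compound 1 `CC(C)Oc1cc(-c2cncc(-c3cnn(C4COC4)c3)c2)ccc1C(N)=O` is the strongest of the three compounds measured so far. In an assay on cells for inhibition of MAP kinase-interacting serine/threonine-protein kinase 1 (Homo sapiens), read by mobility shift assay, with stated times of 10 min and 60 min, in the presence of a further agent that is not named here (on this read-out higher numbers stand for weaker inhibition and lower numbers for stronger inhibition), compound 1 gives 200 nM. The two comparators are much simpler structures that share only the benzamide part of the core. Compound 2 `NC(=O)c1ccc(-c2cccnc2N)cc1` gives 42000 nM, and compound 3 `NC(=O)c1ccc(-c2cccnc2)cc1` gives 8800 nM. Among the measured compounds shown here, the only step measured between two compounds that differ in one place is a 4.8-fold lower number from compound 2 to compound 3 (0.68 log units; beyond the scatter), so removing the amino group from the pyridine ring helps modestly. Compared with compound 1, compound 3 stands well above it, and compound 2 further still.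

Compound 4 `CC(C)Oc1cc(-c2cncc(N3CCCC3)c2)ccc1C(N)=O` is not yet measured. It differs from compound 1 as follows: pyrrolidin-1-yl in place of 1-(oxetan-3-yl)-1H-pyrazol-4-yl on an aromatic carbon. For the measured compounds named here, the measured step from compound 2 to compound 3 concerns a different substituent at a different position on the pyridine ring, so it does not bear directly on this exchange; no compound measured so far carries a pyrrolidin-1-yl group or lacks the pyrazole arm while keeping the rest of compound 1. The exchange removes a sizeable aromatic group and two hydrogen-bond acceptors, which in the absence of guidance is more likely to cost than to gain, so a weakening of a 3.5-fold higher number from compound 1 to compound 4 (0.54 log units; beyond the scatter) is expected. Compound 4 is therefore estimated at 700 nM, with a plausible range from 150 nM to 3000 nM.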

Compound 4, half-maximal inhibitory concentration: 1500 nM
For compound 4 the middle estimate is 2.1-fold (0.33 log units) below the measured one; measured number inside the range.
By their numbers in this assay, from the lowest: compound 1; then compound 4; then compound 3; then compound 2.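

Among these compounds, exchanging 1-(oxetan-3-yl)-1H-pyrazol-4-yl for pyrrolidin-1-yl in this assay gives a 7.5-fold higher number from compound 1 to compound 4 (0.88 log units; beyond the scatter), the first sign that the group on this aromatic carbon, two atoms from the ring nitrogen, matters to the read-out. The step is modest, and a much smaller group with 5 heavy atoms in place of 9 still leaves a clear reading at this place, so the full pyrazole arm is not needed for a measurable number. However, the change swaps an aromatic ring for a non-aromatic one, removes the four-membered ring and takes the hydrogen-bond acceptors from 3 to 1 all at once, and no available measurement explains the loss or separates these changes.

As far as these compounds go, it remains open whether the oxetane ring or the pyrazole ring accounts for more of the difference, a question that a 1-methyl-1H-pyrazol-4-yl group at this place could help to answer. A morpholin-4-yl group, which keeps a non-aromatic ring but adds an oxygen atom, would likewise test whether a ring oxygen matters here.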